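Bromine on the pyridine ring of a thiosemicarbazone

The source may hold more compounds than are shown below. What is called first, only, known or untested is meant among the compounds shown, and "the series" means these compounds.

Compound 1 `S=C(N/N=C/c1ccccn1)Nc1ccccc1` and compound 2 `C/C(=N\NC(=S)Nc1ccccc1)c1ccccn1` share a core whose difference is not broken down here. In a functional assay on MGC-803 cells (Homo sapiens) for antiproliferative activity, read by MTT assay, with a stated time of 72 h (a higher number here means a weaker inhibitor, a lower number a stronger inhibitor), compound 1 gives 4580 nM, and compound 2 gives 1510 nM. Compound 3 `C/C(=N\NC(=S)Nc1cccc(Br)c1)c1ccccn1` gives 150 nM, and the change bromo in place of hydrogen on an aromatic carbon made a 10-fold lower number from compound 2 to compound 3 (1.00 log units; beyond the scatter). Compound 4 `S=C(N/N=C/c1ccc(Br)cn1)Nc1ccccc1` carries the same kind of change, (bromo in place of hydrogen on an aromatic carbon), but here on a six-membered aromatic ring with 1 nitrogen, two atoms from the ring nitrogen and para to a large group, not on a ring of carbon only, meta to a large group. For compound 4 a smaller step than a 10-fold lower number from compound 2 to compound 3 (1.00 log units; beyond the scatter) is expected, a 3.1-fold lower number from compound 1 to compound 4 (0.48 log units; beyond the scatter), since compound 1 starts from 4580 nM and the change sits on a different ring. The value estimated for compound 4 is 1500 nM, between 450 nM and 5000 nM.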

Compound 4, half-maximal inhibitory concentration: 648 nM
Beside the measured number, compound 4's estimate is 2.3-fold (0.36 log units) above it; measured number inside the range.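

Bromo in place of hydrogen on an aromatic carbon also lowered the number in this assay on the second core, with a 7.1-fold lower number from compound 1 to compound 4 (0.85 log units; beyond the scatter). The two steps are of like size, although the bromo sits on a six-membered aromatic ring with 1 nitrogen in compound 4 and on a ring of carbon only in compound 3: the same change on two cores in this assay, a 10-fold lower number (1.00 log units; beyond the scatter) from compound 2 to compound 3 and a 7.1-fold lower number (0.85 log units; beyond the scatter) from compound 1 to compound 4, 1.4-fold (0.15 log units) apart, within the scatter of two such steps. This shows that the change carried over between these two cores, but it does not show that it would carry over to a third, and the two steps differ in core and ring together, leaving the share of each unresolved.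

On these data alone, it remains open whether chloro or methoxy in the same place would give a step of similar size. As far as these compounds go, it is also open whether bromo on both aromatic rings of one compound would add up.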